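A few compounds are considered here, and "the series" means these few. Any claim that something is new, unique, unknown or untested is made for them only; others in the source may bear on it.

Measured in a functional assay on HT-29 cells (Homo sapiens) for inhibition, read by MTT assay, with a stated time of 48 h; a higher number here means a weaker inhibitor, a lower number a stronger inhibitor:
compound 1, `Cc1ccc(NC(=O)NC(=O)c2ccc(OCc3ccccc3)cc2)cc1-c1nc2ccccc2[nH]1`: 16400 nM
compound 2, `Cc1ccc(NC(=O)NC(=O)c2ccc(OCc3ccccc3Cl)cc2)cc1-c1nc2ccccc2[nH]1`: 9010 nM

Of these two numbers compound 2 has the lower one, but the step of a 1.8-fold lower number from compound 1 to compound 2 (0.26 log units; within the scatter) lies within the scatter, so the two compounds are not separated. Compound 3, `Cc1ccc(NC(=O)NC(=O)c2ccc(OCc3ccc(F)cc3)cc2)cc1-c1nc2ccccc2[nH]1`, differs from compound 2 by 4-fluorophenyl in place of 2-chlorophenyl on a saturated chain carbon bound to an oxygen on an aromatic ring. For the measured compounds named here, the only measured step in this region is a 1.8-fold lower number from compound 1 to compound 2 (0.26 log units; within the scatter), which stayed within the scatter, so no step beyond the scatter is expected in this assay. Compound 3 is expected to give about 12000 nM, between 4000 nM and 36000 nM, which means an expected step of a 1.3-fold higher number from compound 2 to compound 3 (0.12 log units; within the scatter).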

Compound 3, half-maximal inhibitory concentration: 980 nM
Compound 3: the middle estimate sits 12-fold (1.09 log units) above what was measured; measured number outside the range, below it.
By their numbers in this assay, from the lowest: compound 3; then compounds 2 and 1 (each within the scatter of the next).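

In this assay the ring on a saturated chain carbon bound to an oxygen on an aromatic ring proves sensitive to its substituent: 4-fluorophenyl in place of 2-chlorophenyl gives a 9.2-fold lower number from compound 2 to compound 3 (0.96 log units; beyond the scatter) and fluoro in place of hydrogen gives a 17-fold lower number from compound 1 to compound 3 (1.22 log units; beyond the scatter) on the same core. Substitution alone does not account for this, as the 2-chlorophenyl of compound 2 did not separate from the unsubstituted ring of compound 1.

The compounds shown leave open whether the identity of the halogen or its place on the ring carries the step, which 4-chlorophenyl or 2-fluorophenyl would settle, and how a methoxy group or an amine would read there. Nothing available explains the result.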